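The compounds below may be only part of what the source reports. "The series", "measured", "known", "first", "only" and "open" are said of these compounds alone.

Among the compounds with values here, compound 2, `COC(=O)CCCCCCCCC(O)CN`, is the weaker of the two compounds measured so far in a functional assay on A549 cells (Homo sapiens) for cytotoxicity, read by MTT assay; a lower number here means a stronger inhibitor, a higher number a weaker inhibitor: compound 2 gives 7890 nM, while its nearest neighbour, compound 1, `CCCCCCCCCC(O)CN`, gives 6780 nM, and the step of a 1.2-fold higher number from compound 1 to compound 2 (0.07 log units; within the scatter) stays within the scatter, so the two numbers cannot be told apart. Compound 3, `NCC(O)CCCCCCCCC(=O)O`, differs from compound 2 by hydrogen in place of methyl on an oxygen next to a carbonyl group. Within the data shown here, only one measured step bears on this, the exchange of methoxycarbonyl for methyl on a saturated chain carbon, which read a 1.2-fold higher number from compound 1 to compound 2 (0.07 log units; within the scatter) and lay within the scatter; it touches the same methoxycarbonyl group but in the other direction of growth, and no step that strips a methyl from an oxygen has been measured. The expectation for compound 3 is therefore a step of a 1.0-fold higher number from compound 2 to compound 3 (0.01 log units; within the scatter) in this assay, nothing beyond the scatter. Compound 3 is estimated at 8000 nM, with a range from 3500 nM to 18000 nM.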

Compound 3, half-maximal inhibitory concentration: "not active" (no number reported)
Compound 3 has no reported number here; there is nothing to compare the estimate with.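

In this assay, within the data shown here, compound 3 is recorded as "not active" without a number, so no step from compound 2 to compound 3 can be read. The compounds shown leave open how far methoxycarbonyl to carboxy moves the number. Nothing measured here bears on this result.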